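This account rests on a few compounds, and the source may have more. Where it says the series, first, only, none or still open, it means among the compounds named here.

Compound 1 `CC1=C(/C=C/C(=O)/C=C/c2ccccc2F)C(C)(C)CCC1O` carries a 2-fluorophenyl group at the end of its dienone chain. In a functional assay on CWR22R cells (Homo sapiens) for cytotoxicity, read by MTT assay, with a stated time of 72 h (on this read-out higher numbers stand for weaker inhibition and lower numbers for stronger inhibition), compound 1 gives 3300 nM, the lowest of the three numbers in hand. Compound 2 `CC1=C(/C=C/C(=O)/C=C/c2ccc(C(F)(F)F)cc2F)C(C)(C)CCC1O` gives 3800 nM in this assay, and the step of a 1.2-fold higher number from compound 1 to compound 2 (0.06 log units; within the scatter) lies within the scatter. Compound 3 `CC1=C(/C=C/C(=O)/C=C/c2c(F)cccc2C(F)(F)F)C(C)(C)CCC1O` gives 8900 nM, and the step of a 2.7-fold higher number from compound 1 to compound 3 (0.43 log units; beyond the scatter) is a modest weakening. Compound 4 `CC1=C(/C=C/C(=O)/C=C/c2cccc(C#N)c2)C(C)(C)CCC1O` differs from compound 1 by 3-cyanophenyl in place of 2-fluorophenyl on a double-bonded chain carbon bound to a double-bonded chain carbon. Neither measured step bears on this change directly: both swapped hydrogen for trifluoromethyl on a ring that kept its fluorine, whereas compound 4 removes the fluorine and brings in a nitrile. What the two steps do show is that altering this aromatic ring moved the number little or only modestly upward. Compound 4 is therefore expected to give roughly 4000 nM in this assay, between 1500 nM and 11000 nM, meaning an expected step of a 1.2-fold higher number from compound 1 to compound 4 (0.08 log units; within the scatter) that may well fall within the scatter.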

Compound 4, half-maximal inhibitory concentration: 2200 nM
The estimate for compound 4 lay 1.8-fold (0.26 log units) above the measured number, within the range that was stated.
By their numbers in this assay, from the lowest: compounds 4, 1 and 2 (each within the scatter of the next); then compound 3.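

In this assay, among these compounds, the change gives a 1.5-fold lower number from compound 1 to compound 4 (0.18 log units; within the scatter) and is the first one here in which the fluorine leaves the ring. It shows that 3-cyanophenyl can take the place of 2-fluorophenyl on a double-bonded chain carbon bound to a double-bonded chain carbon while the number stays within the scatter, so among these compounds fluorine on this ring is not required to stay level with compound 1, although the single swap removes fluorine and brings in a nitrile together and cannot tell their contributions apart. Nothing at hand offers an explanation for this result. The compounds shown leave open how a plain phenyl group would compare with compound 1 and compound 4. They also leave open whether an amine or a carboxylic acid on this ring would keep the number within the scatter.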